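The source may report more compounds than this note shows. Statements on the series, on what has been measured and on what is new or still open speak of the compounds shown alone.

Compound 1 `COc1ccc(-c2cc(/C=C/C(=O)c3ccc(N)cc3)[nH]n2)cc1`: -61%
Compound 2 `COc1cc(-c2cc(/C=C/C(=O)c3ccc(N)cc3)[nH]n2)cc(OC)c1OC`: -80%
Compound 3 `COc1ccc(C(=O)/C=C/c2cc(-c3cc(OC)c(OC)c(OC)c3)n[nH]2)cc1OC`: -88%

In a functional assay on SF-268 cells (Homo sapiens) for cytotoxicity, read by sulforhodamine B assay, with a stated time of 48 h, tested at 100 uM (a lower number here means a stronger effect, a higher number a weaker effect of the compound at the concentration tested), compound 2 gives -80%, the second highest of the three numbers. For the measured compounds named here, its nearest neighbour is compound 3, reached by the only measured step, a number 8 percentage points lower from compound 2 to compound 3 (within the scatter); its furthest is compound 1, whose number is higher beyond the scatter. Compound 4 `COc1ccc(-c2cc(/C=C/C(=O)c3ccc(N)cc3)[nH]n2)cc1OC` differs from compound 2 by hydrogen in place of methoxy on an aromatic carbon. The measured step alters the ring on the carbonyl side, not this ring, so it bears only loosely on the change. Compound 1, which carries a single methoxy on the same ring, gives -61%, a weaker effect than compound 2. Compound 4 is therefore expected to land between them, at -70% with a range of -88% to -52%. The expected step is a number 10 percentage points higher from compound 2 to compound 4 (within the scatter), a rise in the number of modest size.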

Compound 4, a percentage reported as activity, at one concentration (the size of the read-out at that concentration, not a potency): -80%
Compound 4: the middle estimate sits 10 percentage points above what was measured; the range from low to high includes it.
By their numbers in this assay, from the lowest: compounds 3, 2 and 4 (each within the scatter of the next); then compound 1.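

In this assay, hydrogen in place of methoxy on this aromatic carbon gives no change at the digits printed from compound 2 to compound 4 (within the scatter), so this methoxy can be lost without a readable change. The reverse kind of change, methoxy in place of hydrogen, gives a number 19 percentage points lower from compound 1 to compound 4 (beyond the scatter), so on this ring one added methoxy counts while the further one in compound 2 does not. Nothing available explains this difference between the two steps.

Going by these compounds, a fluorine, a hydroxyl or an amine at this position remains open. So does whether the same picture would hold at lower concentrations, where the effect of each compound could be compared at those concentrations.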